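A further methoxy on compound 2

The source may hold more compounds than are shown below. What is called first, only, known or untested is meant among the compounds shown, and "the series" means these compounds.

Values in a functional assay for inhibition, with Homo sapiens as the target (a higher number here means a weaker inhibitor, a lower number a stronger inhibitor), so far
- compound 1 `CCOc1c(C(=O)Nc2nn[nH]n2)sc2ccc(OC)cc12` gives > 100000 nM as a limit
- compound 2 `COc1ccc2sc(C(=O)Nc3nn[nH]n3)c(Oc3ccccc3)c2c1` gives 10100 nM
- compound 3 `COc1ccc2sc(C(=O)Nc3nn[nH]n3)c(OCc3ccccc3)c2c1` gives 23400 nM

In this assay compound 2 gives 10100 nM as the lowest number shown, and compound 3 comes nearest at 23400 nM in the series. The change to compound 4 `COc1cc2sc(C(=O)Nc3nn[nH]n3)c(Oc3ccccc3)c2cc1OC` is methoxy in place of hydrogen on an aromatic carbon, ortho to a methoxy group (methoxy in place of hydrogen on an aromatic carbon). Going by the values given here, none of the measured steps touches this carbon, so they offer only a scale of size: an at least 9.9-fold lower number from compound 1 to compound 2 (0.99 log units; beyond the scatter) and an at least 4.2-fold lower number from compound 1 to compound 3 (0.63 log units; beyond the scatter), both reckoned from a limit, and a 2.3-fold higher number from compound 2 to compound 3 (0.36 log units; beyond the scatter) as the one exact step. The expected change is a 1.0-fold lower number from compound 2 to compound 4 (0.00 log units; within the scatter), with no direction to be read from these data. For compound 4 the estimate is 10000 nM, with an expected range from 3000 nM to 40000 nM in this assay overall.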

Compound 4, half-maximal inhibitory concentration: 5700 nM
The estimate for compound 4 lay 1.8-fold (0.24 log units) above the measured number; low and high end bracket the measured number.
By their numbers in this assay, from the lowest: compounds 4 and 2 (each within the scatter of the next); then compound 3. At a limit, above all of these: compound 1.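

In this assay, methoxy in place of hydrogen on this aromatic carbon, ortho to a methoxy group, gives a 1.8-fold lower number from compound 2 to compound 4 (0.25 log units; within the scatter). Going by these compounds alone, this is the first measured change at this carbon, and it shows that the carbon can carry a second methoxy while the number stays within the scatter of compound 2. Nothing measured here bears on the cause of this result.

As far as these compounds go, whether an amine, a carboxylic acid or a longer chain on this carbon would leave the number as close remains open. So does whether the added methoxy would give the same result with the benzyl of compound 3 on the oxygen.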